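The source may report more compounds than this note shows. Statements on the series, on what has been measured and on what is new or still open speak of the compounds shown alone.

Compound 1 `COc1ccc(-n2cc(CSC(=S)N3CCN(C(=O)OC(C)(C)C)CC3)nn2)cc1` — in a functional assay on PC-3 cells (Homo sapiens) for inhibition, read by MTT assay, with a stated time of 72 h (on this read-out higher numbers stand for weaker inhibition and lower numbers for stronger inhibition), compound 1 gives > 128000 nM, a limit of the assay.
Compound 2 `Cc1ccc(-n2cc(CSC(=S)N3CCN(C(=O)OC(C)(C)C)CC3)nn2)cc1` — in this assay compound 2 gives > 128000 nM, also a limit.
Compound 3 `S=C(SCc1cn(Cc2ccc(Cl)c(Cl)c2)nn1)N1CCNCC1` — in this assay compound 3 gives "not determined" (no result reported).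

Compound 3 therefore stands without a number; the two other values shown are limits, as the limit of > 128000 nM in this assay, at which 2 of the 3 values shown sit, records. Within the data shown here, the only measured step, a step that the two limits leave unreadable from compound 1 to compound 2, is unreadable from its two limits. The change to compound 4 `CC(C)(C)OC(=O)N1CCN(C(=S)SCc2cn(Cc3ccc(Cl)c(Cl)c3)nn2)CC1` is tert-butoxycarbonyl in place of hydrogen on an amine nitrogen in a ring. Among the measured compounds shown here, no measured step covers this change, so its size and direction in this assay cannot be read from compounds 1 and 2, which carry the same tert-butoxycarbonyl group and both sit at the limit (the limit of > 128000 nM in this assay, at which 2 of the 3 values shown sit). Compound 4 is expected at 150000 nM, within 30000 nM to 600000 nM, most likely reported only as a limit.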

Compound 4, half-maximal inhibitory concentration: > 128000 nM
Compound 4: a limit, no number; the forecaster's own chance of this, stated with the estimate: 70%; the middle value does not contradict the limit.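

Compounds 1, 2 and 4 yield no new readable step, as all three values are limits in this assay: the limit of > 128000 nM in this assay, at which 3 of the 4 values shown sit.

On these data alone, the effect of tert-butoxycarbonyl in place of hydrogen stays open, with no number for compound 3 and none beyond a limit for compound 4.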